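This account rests on a few compounds, and the source may have more. Where it says the series, first, only, none or still open, it means among the compounds named here.

Compound 1 `Cc1cc(=O)oc2cc(OCC(O)CN3CCC(C(N)=O)CC3)ccc12` carries a methyl group on its shared core. In an ADME assay on A549 cells (Homo sapiens) for cytotoxicity, read by CellTiter-Glo (a lower number here means that less compound is tolerated, a higher number that more compound is tolerated), compound 1 gives > 100000 nM, which is a limit of the assay rather than a number. Compound 2 `Cc1c(Cc2ccc(C(C)(C)C)cc2)c(=O)oc2cc(OCC(O)CN3CCC(C(N)=O)CC3)ccc12` gives 14700 nM in this assay. Compound 3 `Cc1c(Cc2ccc(Br)cc2)c(=O)oc2cc(OCC(O)CN3CCC(C(N)=O)CC3)ccc12` gives > 100000 nM in this assay, again a limit and not a number. In this assay there was an at least 6.8-fold lower number from compound 1 to compound 2 (0.83 log units; beyond the scatter), and an at least 6.8-fold higher number from compound 2 to compound 3 (0.83 log units; beyond the scatter), while the comparison of compound 1 with compound 3 is a step that the two limits leave unreadable from compound 1 to compound 3. Much of what is known here rests on (the limit of > 100000 nM in this assay, at which 2 of the 3 values shown sit).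

Compound 4 `NC(=O)C1CCN(CC(O)COc2ccc3c(C4CC4)cc(=O)oc3c2)CC1` differs from compound 1 in one place: cyclopropyl in place of methyl on an aromatic carbon. Among the compounds with values here, none of the three measured steps touches this group; all of them concern a benzyl group on another aromatic carbon, so no measured step bears directly on the change. The expectation is therefore a small step, with a number no higher from compound 1 to compound 4 (the limit leaves the size open) expected to stay within the scatter. Compound 4 is estimated to give 100000 nM in this assay, within a range from 30000 nM to 300000 nM.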

Compound 4, half-maximal cytotoxic concentration: > 100000 nM
Compound 4 was reported as a limit (the forecaster's own chance of this, stated with the estimate: 70%); the middle value sits exactly at the limit.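

Within the data shown here, compound 1 and compound 4 both stand at a limit of the assay and not at a number, so no step between them can be read: the limit of > 100000 nM in this assay, at which 3 of the 4 values shown sit. The compounds shown leave open whether cyclopropyl in place of methyl changes the tolerated concentration at all, and by how much.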